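A few compounds are considered here, and "the series" means these few. Any claim that something is new, unique, unknown or untested is made for them only; others in the source may bear on it.

Compound 2 `Fc1ccc(CCCCN2CCN(c3ncc(F)cn3)CC2)cc1` in an assay (Cavia porcellus) for displacement of a labelled ligand from Sigma non-opioid intracellular receptor 1 (Homo sapiens) (a lower number here means a stronger inhibitor, a higher number a weaker inhibitor), gives 23 nM, the lowest of the two numbers in hand. Compound 1 `O=C(OC(CCCN1CCN(c2ncc(F)cn2)CC1)c1ccc(F)cc1)c1ccccc1` in this assay gives 3500 nM. Compound 3 `O=C(NC(CCCN1CCN(c2ncc(F)cn2)CC1)c1ccc(F)cc1)c1ccc(F)cc1` in this assay gives > 100 nM, which is a limit of the assay and not a number. The change from compound 2 to compound 4 `NC(CCCN1CCN(c2ncc(F)cn2)CC1)C1CCCCC1` is amino(cyclohexyl)methyl in place of 4-fluorobenzyl on a saturated chain carbon, three bonds along the chain from an amine nitrogen in a ring. Going by the values given here, two measured steps touch the same chain carbon: a 150-fold lower number from compound 1 to compound 2 (2.18 log units; beyond the scatter), and an at least 4.3-fold higher number from compound 2 to compound 3 (0.63 log units; beyond the scatter). In both, the bare chain carbon of compound 2 goes with the lower number and any substituent on it with a higher one. The exchange of the aromatic ring for the non-aromatic ring is not covered by any measured pair. With a substituent again placed on that chain carbon, compound 4 is expected to show a higher number, a 13-fold higher number from compound 2 to compound 4 (1.12 log units; beyond the scatter), though the amino group is smaller than the groups in the measured steps. For compound 4 the estimate is 300 nM, with a range from 60 nM to 1500 nM.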

Compound 4, half-maximal inhibitory concentration: 52 nM
Estimate against measurement, compound 4: 5.8-fold (0.76 log units) above, outside the stated range (below it).
By their numbers in this assay, from the lowest: compound 2; then compound 4; then compound 1.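

In this assay, the exchange at this chain carbon costs little: a 2.3-fold higher number from compound 2 to compound 4 (0.35 log units; beyond the scatter), a modest step beyond the scatter, so compound 2 keeps the lowest number. Unlike the benzoyloxy group of compound 1 and its large step, amino(cyclohexyl)methyl shows that a branched group on this saturated chain carbon, with a non-aromatic ring in place of the aromatic one and with a hydrogen-bond donor entering, can keep the number close to that of the unbranched 4-fluorobenzyl. No measured property in hand accounts for this step.

On these data alone, the amino group and the cyclohexyl ring enter together, so their separate shares in the step remain unknown. A plain cyclohexylmethyl group, or an amino group on the chain carbon with the 4-fluorophenyl ring retained, would separate them.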